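Chain shortening and cytotoxicity in HEL cells: next step

The source may hold more compounds than are shown below. What is called first, only, known or untested is meant among the compounds shown, and "the series" means these compounds.

Measured so far:
compound 1, `CCCCCCCCCCCc1cc2cn(COCCO)c(=O)nc2o1`, gives 80000 nM in a functional assay on HEL cells (Homo sapiens), read by microscopy; on this read-out lower numbers stand for higher toxicity in this test and higher numbers for lower toxicity in this test
compound 2, `CCCCCCCCCCc1cc2cn(COCCO)c(=O)nc2o1`, gives 400000 nM in this assay

Among the measured compounds shown here, compound 2 stands at the highest of the two numbers in this assay, the only neighbour being compound 1 with a lower number: a 5.0-fold higher number from compound 1 to compound 2 (0.70 log units; beyond the scatter). For the measured compounds named here, that single step, which removes one carbon from the end of the chain, is the only measured step that bears on the next one.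

Compound 3, `CCCCCCCCc1cc2cn(COCCO)c(=O)nc2o1`, differs from compound 2 by hydrogen in place of ethyl on a saturated chain carbon, eight bonds along the chain from an aromatic carbon. The change runs in the same sense as the measured step, but takes two carbons off the chain rather than one. On the one step shown, a further rise in the minimum cytotoxic concentration is expected for compound 3, plausibly larger than the measured step, though with one data point the size is uncertain, and the number may exceed the range of the test and come back as a limit. The expected step is a 5.0-fold higher number from compound 2 to compound 3 (0.70 log units; beyond the scatter). For compound 3 the estimated value in this assay is 2000000 nM, in the range 400000 nM to 10000000 nM.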

Compound 3, minimum cytotoxic concentration: >= 80000 nM
Compound 3 gave a limit, no number; the forecaster's own chance of this, stated with the estimate: 40%; the middle value does not contradict the limit.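

In this assay compound 3 gives >= 80000 nM, which is a limit of the test and not a number. Hydrogen in place of ethyl, on a saturated chain carbon, eight bonds along the chain from an aromatic carbon, therefore fixes only a direction against the compound with the longer chain, a number no lower from compound 1 to compound 3 (the limit leaves the size open), and the step from compound 2 to compound 3 cannot be read. The series gains no second number along the chain, so the earlier step, a 5.0-fold higher number from compound 1 to compound 2 (0.70 log units; beyond the scatter), is neither extended nor contradicted at this position: the limit of >= 80000 nM in this assay, at which 1 of the 3 values shown sits.

Left open is how the read-out in this assay behaves with a chain shorter than that of compound 3, and whether a longer chain than that of compound 1 carries the numbers lower still. Also open, from the compounds shown here alone, is what an amine or a carboxylic acid in place of the chain would give on the shared core.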